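The compounds below may be only part of what the source reports. "The series", "measured", "known", "first", "only" and "open" are said of these compounds alone.

Measured so far in a functional assay on the whole organism (Hindlimb, strain albino) with Mus musculus as the target, in the maximal electroshock model, with a stated time of 0.5 h; a higher number here means that more compound is needed for the effect, a lower number that less compound is needed:

compound 1 `COc1ccc(C2CC(Nc3nc4ccc([N+](=O)[O-])cc4s3)=NN2C(C)=O)cc1` gives 145 umol/kg
compound 2 `COc1ccc(C2CC(Nc3nc4ccc(Cl)cc4s3)=NN2C(C)=O)cc1O` gives 127 umol/kg
compound 3 `CC(=O)N1N=C(Nc2nc3ccc(Cl)cc3s2)CC1c1ccc(O)cc1` gives 106 umol/kg

Compound 3, at 106 umol/kg, lies within the scatter of both compound 2 and compound 1, so these values do not separate in this assay.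

The step under consideration leads to compound 4 `COc1ccc(C2CC(Nc3nc4ccc(Cl)cc4s3)=NN2C(C)=O)cc1`. The structural change is methyl in place of hydrogen on an oxygen on an aromatic ring, which turns 4-hydroxyphenyl into 4-methoxyphenyl.

Among the measured compounds shown here, only one measured step touches the same substituent: a 1.2-fold lower number from compound 2 to compound 3 (0.08 log units; within the scatter). That step is 4-hydroxyphenyl in place of 3-hydroxy-4-methoxyphenyl, so it is related to the new change but not identical to it. It stays within the scatter. The methoxy-bearing compound 1 at 145 umol/kg and compound 2 at 127 umol/kg also give no sign of a large shift, though neither isolates the change at hand. No step beyond the scatter is therefore expected, and the data offer no firm direction. The estimated step is a 1.1-fold higher number from compound 3 to compound 4 (0.04 log units; within the scatter), which is expected to remain within the scatter. For compound 4 the expected value is 115 umol/kg, with an estimated range from 65 umol/kg to 200 umol/kg.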

Compound 4, dose for half-maximal effect: 93.3 umol/kg
Beside the measured number, compound 4's estimate is 1.2-fold (0.09 log units) above it; the measured number falls inside the stated range.
By their numbers in this assay, from the lowest: compounds 4, 3, 2 and 1 (each within the scatter of the next).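

In this assay, the change from 4-hydroxyphenyl to 4-methoxyphenyl can now be read directly, and methyl in place of hydrogen on this oxygen gives a 1.1-fold lower number from compound 3 to compound 4 (0.06 log units; within the scatter), so the hydroxy hydrogen is not needed to keep the read-out within the scatter of compound 3. Among the compounds shown here, compound 4 also gives two single-place comparisons that the earlier compounds lacked: hydrogen in place of hydroxy on an aromatic carbon gives a 1.4-fold lower number from compound 2 to compound 4 (0.13 log units; within the scatter), and chloro in place of nitro on an aromatic carbon gives a 1.6-fold lower number from compound 1 to compound 4 (0.19 log units; within the scatter), so neither change separates from the scatter, and all four compounds remain unresolved in this read-out. Nothing measured here bears on why these steps remain so small.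

From the compounds shown here alone, whether a carboxylic acid or an amine in place of the methoxy group, or a longer chain such as butoxy on the same oxygen, would give a step beyond the scatter remains open. All four compounds also keep the acetyl group on the shared core, so the effect of replacing it with a longer acyl chain is likewise unknown.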